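Amino in place of methoxy on compound 3

The source may hold more compounds than are shown below. What is called first, only, known or untested is meant among the compounds shown, and "the series" means these compounds.

Measured in a functional assay on A549 cells (Homo sapiens) for inhibition, read by sulforhodamine B assay, with a stated time of 72 h; a lower number here means a stronger inhibitor of growth, a higher number a weaker inhibitor of growth:
compound 1 `NNC(=O)CCc1ccncc1-c1ccc2ccccc2c1` gives > 10000 nM
compound 2 `CCOC(=O)/C=C/c1ccncc1-c1ccc2ccccc2c1` gives 5380 nM
compound 3 `COC(=O)/C=C/c1ccncc1-c1ccc2ccccc2c1` gives 760 nM

Compound 1 reports only a limit, > 10000 nM. Compound 3 holds the lowest number, and the measured gap is a 7.1-fold lower number from compound 2 to compound 3 (0.85 log units; beyond the scatter). The unmeasured compound 4 `NC(=O)/C=C/c1ccncc1-c1ccc2ccccc2c1` carries one change, (amino in place of methoxy on a carbonyl carbon), amino in place of methoxy on a carbonyl carbon. Going by the values given here, two measured steps bear on it. The modest 7.1-fold lower number from compound 2 to compound 3 (0.85 log units; beyond the scatter) involves the group on this same carbonyl, and the large at least 13-fold lower number from compound 1 to compound 3 (1.11 log units; beyond the scatter) starts from a compound with nitrogen on its carbonyl. A higher number is therefore expected in this assay, with a modest to large step. The expected change is a 5.3-fold higher number from compound 3 to compound 4 (0.72 log units; beyond the scatter). Compound 4 is estimated at 4000 nM, with an expected range from 900 nM to 15000 nM.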

Compound 4, concentration for 50% growth inhibition: > 10000 nM
Compound 4 gave a limit, no number; the forecaster's own chance of this, stated with the estimate: 30%; middle value at least 2.5-fold (0.39 log units) away from the limit.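

On this carbonyl carbon, the methoxy of compound 3 cannot be exchanged for amino without a clear loss in this assay: the change gives an at least 13-fold higher number from compound 3 to compound 4 (1.11 log units; beyond the scatter). Compound 4 keeps the double-bonded chain carbon, yet the comparison with the ethyl ester gives only an at least 1.8-fold higher number from compound 2 to compound 4 (0.26 log units; that floor lies within the scatter). The step between compound 1 and compound 4 cannot be read, and compound 4 reports only a limit: the limit of > 10000 nM in this assay, at which 2 of the 4 values shown sit.

The compounds shown leave open how a carboxylic acid or an N-methyl amide on this carbonyl carbon would behave. They also leave open whether any amide here can reach the level of compound 3.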